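The source may hold more compounds than are shown below. What is called first, only, known or untested is meant among the compounds shown, and "the series" means these compounds.

Measured so far:

Compound 1, `Nc1cc(N)c2nc(-c3ccccc3)c(Oc3ccc(Cl)c(Cl)c3)nc2c1`, gives 23400 nM in a functional assay on SK-MEL-2 cells (Homo sapiens) for inhibition, read by sulforhodamine B assay, with a stated time of 48 h; a lower number here means a stronger inhibitor of growth, a higher number a weaker inhibitor of growth.
Compound 2, `CCOC(=O)[C@H](CCC(=O)O)NC(=O)c1ccc(CNc2nc3cc(N)cc(N)c3nc2-c2ccccc2)cc1`, gives 77600 nM in this assay.

Of the two compounds measured, compound 1 stands at the lower number, and its gap to compound 2 lies beyond the usual scatter of this kind of measurement. Nothing more can be drawn from that pair, since the two structures differ in more than one place at once.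

Among the compounds with values here, compound 3, `Nc1cc(N)c2nc(-c3ccccc3)c(Oc3ccc(F)cc3)nc2c1`, is a close relative of compound 1: the only change is 4-fluorophenyl in place of 3,4-dichlorophenyl on an oxygen on an aromatic ring. Within the data shown here, no pair of measured compounds shows a change of this type, so there is no measured step to lean on. The expectation is therefore cautious: a small step toward a higher number, or none that clears the scatter. The step from compound 1 to compound 3 in this assay is estimated at a 1.7-fold higher number from compound 1 to compound 3 (0.23 log units; within the scatter). On that basis compound 3 is expected to give about 40000 nM in this assay, with a plausible range from 12000 nM to 130000 nM.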

Compound 3, concentration for total growth inhibition: < 100000 nM
Compound 3 ended at the assay's limit (the forecaster's own chance of this, stated with the estimate: 15%); the middle value does not contradict the limit.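

Compound 3 sits at a limit of the assay rather than at a readable number, so no step from compound 1 to compound 3 can be read: the limit of < 100000 nM in this assay, at which 1 of the 3 values shown sits.

The compounds shown leave open whether 4-fluorophenyl in place of 3,4-dichlorophenyl on an oxygen on an aromatic ring changes growth inhibition at all, and in which direction.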